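Fluoro for methoxy on a triazole-hydrazone aryl ring

This account rests on a few compounds, and the source may have more. Where it says the series, first, only, none or still open, it means among the compounds named here.

The study concerns two measured hydrazones built on a shared core and a third one that awaits its number. Compound 1 `Oc1ccc(/C=N/n2cnnc2)cc1` and compound 2 `COc1ccc(/C=N/n2cnnc2)c(OC)c1` were both examined in an assay for inhibition of Alpha amylase (Homo sapiens), with a stated time of 10 min; on this read-out lower numbers stand for stronger inhibition and higher numbers for weaker inhibition. In this assay compound 1 gives 2990 nM, and compound 2 gives 4370 nM. Of the two numbers, compound 2 has the higher one, yet the gap to compound 1 is within the scatter, so the two results are not distinguished from one another; neither can be called stronger or weaker.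

Compound 3 `COc1ccc(/C=N/n2cnnc2)c(F)c1` is the untested member. It differs from compound 2 by one change: fluoro in place of methoxy on an aromatic carbon. Among the compounds with values here, no step between measured compounds of this set follows a move of this kind, so there is no directly comparable precedent in this assay. Compound 3 is therefore expected to land close to compound 2, with a step from compound 2 to compound 3 of a 1.2-fold lower number from compound 2 to compound 3 (0.10 log units; within the scatter) and no direction beyond the scatter. For compound 3 the estimated result in this assay is 3500 nM, with an expected range from 1500 nM to 9000 nM.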

Compound 3, half-maximal inhibitory concentration: 2900 nM
For compound 3 the middle estimate is 1.2-fold (0.08 log units) above the measured one, and the stated range covers the measured number.
By their numbers in this assay, from the lowest: compounds 3, 1 and 2 (each within the scatter of the next).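

In this assay, within the data shown here, fluoro in place of methoxy on the aromatic carbon ortho to a group of 7 heavy atoms gives a 1.5-fold lower number from compound 2 to compound 3 (0.18 log units; within the scatter), the first step that can be read at this position. The step lies within the scatter, so the two compounds are not told apart, even though the methoxy with its 2 heavy atoms and 1 hydrogen-bond acceptor gives way to a fluoro with 1 heavy atom and 0 hydrogen-bond acceptors; at this position, then, the read-out does not separate these two groups. No measurement here bears on what lies behind this result, and a single step within the scatter does not supply one.

What the compounds shown leave open is whether any group on this carbon moves the number beyond the scatter, for instance an amine, a carboxylic acid, a chloro or a longer chain such as butoxy. Also open, going by these compounds, is whether the same exchange of methoxy for fluoro would read the same way on the other methoxy-bearing carbon, the one meta to this position.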